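The source may hold more compounds than are shown below. What is called first, only, known or untested is meant among the compounds shown, and "the series" means these compounds.

In an ADME assay on HepG2 cells (Homo sapiens) for cytotoxicity, read by MTT assay, with a stated time of 48 h (a higher number here means a weaker inhibitor, a lower number a stronger inhibitor), compound 1 (`O=S(=O)(c1cccc(-c2ccc3ncnc(Nc4ccc(OCc5cccc(F)c5)c(Cl)c4)c3c2)c1)N1CCOCC1`) gives > 15000 nM, which is a limit of the assay and not a number. Compound 2 (`O=S(=O)(c1ccc(-c2ccc3ncnc(Nc4ccc(OCc5cccc(F)c5)c(Cl)c4)c3c2)cc1)N1CCSCC1`) gives > 15000 nM, which is likewise a limit. Compound 1 therefore has no exact position on the scale, and the data show only (the limit of > 15000 nM in this assay, at which 2 of the 2 values shown sit).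

Compound 3 (`CS(=O)(=O)c1cccc(-c2ccc3ncnc(Nc4ccc(OCc5cccc(F)c5)c(Cl)c4)c3c2)c1`) keeps the core of compound 1 but has methyl in place of morpholin-4-yl on a sulfonyl sulfur. For the measured compounds named here, no measured step shows what this change does in this assay. The expectation rests only on compound 1 and compound 2, which share (the limit of > 15000 nM in this assay, at which 2 of the 2 values shown sit). The estimated step that the limit leaves unreadable from compound 1 to compound 3 is expected to stay within the scatter, with neither direction favoured. For compound 3 the estimated value is 20000 nM, with an expected range from 8000 nM to 50000 nM.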

Compound 3, half-maximal inhibitory concentration: > 15000 nM
Compound 3 gave a limit, no number (the forecaster's own chance of this, stated with the estimate: 65%); the middle value lies beyond the limit too.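

Compound 1 and compound 3 both give only a limit in this assay, so no step between them can be read: the limit of > 15000 nM in this assay, at which 3 of the 3 values shown sit.

The compounds shown leave open whether methyl in place of morpholin-4-yl on a sulfonyl sulfur shifts the half-maximal inhibitory concentration at all, and in which direction.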